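Furan-2-yl in place of thiophen-3-yl on the saturated carbon

The source may report more compounds than this note shows. Statements on the series, on what has been measured and on what is new or still open speak of the compounds shown alone.

Compound 3 `CCOC(=O)C1=C(C)N/C(=N\C#N)NC1c1ccsc1` gives 461 nM in an assay on HEK293 cells for displacement of a labelled ligand from adenosine receptor A2b (Homo sapiens), with a stated time of 30 min (a lower number here means a stronger inhibitor, a higher number a weaker inhibitor), and so stands second highest of the three numbers obtained so far. Compound 1 `CCOC(=O)C1=C(C)N/C(=N\C#N)NC1c1cccs1` gives 51 nM in this assay, while compound 2 `CC1=C(C(=O)OC(C)C)C(c2ccsc2)N/C(=N/C#N)N1` gives 647 nM. Two single-point steps connect these: a 9.0-fold higher number from compound 1 to compound 3 (0.96 log units; beyond the scatter), and a 1.4-fold lower number from compound 2 to compound 3 (0.15 log units; within the scatter). Compound 4 `CCOC(=O)C1=C(C)N/C(=N\C#N)NC1c1ccco1` differs from compound 3 in one place: furan-2-yl in place of thiophen-3-yl on a saturated ring carbon. Of the measured steps, only a 9.0-fold higher number from compound 1 to compound 3 (0.96 log units; beyond the scatter) bears on this change, since furan-2-yl shares its manner of attachment with the thiophen-2-yl of compound 1, whereas the ester variation in a 1.4-fold lower number from compound 2 to compound 3 (0.15 log units; within the scatter) stayed within the scatter and says nothing about the aromatic ring. Going by the values given here, the oxygen for sulfur exchange itself has no measured counterpart here, so part of the difference remains uncertain. Compound 4 is therefore expected to give 110 nM in this assay, with a range from 35 nM to 400 nM. This estimate means an expected step of a 4.2-fold lower number from compound 3 to compound 4 (0.62 log units; beyond the scatter) for compound 4, a lower number beyond the scatter.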

Compound 4, inhibition constant: 900 nM
The estimate for compound 4 lay 8.2-fold (0.91 log units) below the measured number; measured number outside the range, above it.
By their numbers in this assay, from the lowest: compound 1; then compounds 3, 2 and 4 (each within the scatter of the next).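

In this assay the change from thiophen-2-yl to furan-2-yl on the saturated ring carbon gives an 18-fold higher number from compound 1 to compound 4 (1.25 log units; beyond the scatter) and so the low number of compound 1 does not follow from the manner of attachment of the ring alone. Furan-2-yl and thiophen-3-yl, by contrast, are not told apart at this position, with a 2.0-fold higher number from compound 3 to compound 4 (0.29 log units; within the scatter) and so, among the ethyl esters, only thiophen-2-yl stands apart from the other two rings. Nothing available accounts for this difference between two rings attached in the same manner.

The compounds shown leave open how furan-3-yl or a phenyl ring would read on this carbon. They also leave open whether replacing the ethoxycarbonyl group with an isopropyl ester would matter as little with thiophen-2-yl as it does with thiophen-3-yl.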